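Swapping nitro for ethoxycarbonyl on a sulfonamide core

This account rests on a few compounds, and the source may have more. Where it says the series, first, only, none or still open, it means among the compounds named here.

Of the compounds shown here, two sharing one sulfonamide core have been measured. Compound 1 `Cc1noc(NS(=O)(=O)c2cccc3c(N(C)C)cccc23)c1Cc1ccccc1` gives 50000 nM in an assay on VSM-A10 cells for antagonist activity at Endothelin-1 receptor (Rattus norvegicus) (on this read-out lower numbers stand for stronger inhibition and higher numbers for weaker inhibition), and compound 2 `Cc1noc(NS(=O)(=O)c2cccc3c(N(C)C)cccc23)c1[N+](=O)[O-]` gives 17300 nM in this assay. Among the measured compounds shown here, the only step seen so far is a 2.9-fold lower number from compound 1 to compound 2 (0.46 log units; beyond the scatter). For the measured compounds named here, compound 2 therefore has the lower of the two numbers, with compound 1 as its only neighbour.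

Compound 3 `CCOC(=O)c1c(C)noc1NS(=O)(=O)c1cccc2c(N(C)C)cccc12` differs from compound 2 by a single change, (ethoxycarbonyl in place of nitro on an aromatic carbon). Going by the values given here, no measured pair replaces a nitro with an ethoxycarbonyl, so the one recorded step speaks to this change only indirectly: it shows that a group at this position can move the number by a modest amount. Among the compounds with values here, with that as the sole guide, a small step in this assay is expected for compound 3, in either direction, and most likely not beyond the scatter.

The estimate for compound 3 is 20000 nM, within 6000 nM to 60000 nM, which corresponds to an expected step of a 1.2-fold higher number from compound 2 to compound 3 (0.06 log units; within the scatter).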

Compound 3, half-maximal inhibitory concentration: 31000 nM
The estimate for compound 3 lay 1.6-fold (0.19 log units) below the measured number; measured number inside the range.
By their numbers in this assay, from the lowest: compounds 2, 3 and 1 (each within the scatter of the next, the first and the last beyond it).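

Ethoxycarbonyl in place of nitro on this aromatic carbon gives a 1.8-fold higher number from compound 2 to compound 3 (0.25 log units; within the scatter), so in this assay this change, which brings 5 heavy atoms where nitro has 3, does not separate the two compounds. Ethoxycarbonyl in place of benzyl gives a 1.6-fold lower number from compound 1 to compound 3 (0.21 log units; within the scatter), so compound 3 cannot be told apart from compound 1 either, even though compound 1 and compound 2 do differ beyond the scatter. Nothing available explains these small steps.

Still open, as far as these compounds go, is whether a carboxylic acid, an amine or a longer ester chain on this carbon would give a step beyond the scatter. The three compounds also vary only this one position, so they cannot show whether these steps would stay as small on a different core.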